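Replacing the 4-acetylpiperazin-1-yl group of compound 2

The source may report more compounds than this note shows. Statements on the series, on what has been measured and on what is new or still open speak of the compounds shown alone.

In a physicochemical assay for solubility, read by HPLC, in phosphate buffer, at pH 6.8 (on this read-out higher numbers stand for higher solubility and lower numbers for lower solubility), compound 2 (`CC[C@@H]1CC[C@@H](C(=O)N2CCN(C(C)=O)CC2)N1C(=O)C1=C(C(C)C)N2C(=N[C@@](C)(c3ccc(Cl)cc3)[C@H]2c2ccc(Cl)cc2)S1`) gives 34 ug/mL as the lowest of three numbers, while compound 1 (`CC(=O)N1CCN(C(=O)[C@@H]2CC[C@@H](C)N2C(=O)C2=C(C(C)C)N3C(=N[C@@](C)(c4ccc(Cl)cc4)[C@H]3c3ccc(Cl)cc3)S2)CC1`) gives 79 ug/mL and compound 3 (`CC(=O)N1CCN(C(=O)[C@@H]2CC[C@@H](C)N2C(=O)C2=C(C(C)C)N3C(=N[C@@](C)(c4ccc(Cl)cc4)[C@H]3c3ccc(Cl)cc3)S2)C[C@H]1C`) gives 72 ug/mL on the same read-out. Compound 4 (`CC[C@@H]1CC[C@@H](C(=O)N2CCN(C)[C@@H](C)C2)N1C(=O)C1=C(C(C)C)N2C(=N[C@@](C)(c3ccc(Cl)cc3)[C@H]2c2ccc(Cl)cc2)S1`) differs from compound 2 in one place (3,4-dimethylpiperazin-1-yl in place of 4-acetylpiperazin-1-yl on a carbonyl carbon): 3,4-dimethylpiperazin-1-yl stands in place of 4-acetylpiperazin-1-yl on a carbonyl carbon. Going by the values given here, two measured steps bear on this only loosely. Methyl in place of hydrogen on a saturated ring carbon gave a 1.1-fold lower number from compound 1 to compound 3 (0.04 log units; within the scatter) and the other measured step, also an added methyl, gave a 2.3-fold lower number from compound 1 to compound 2 (0.37 log units; beyond the scatter) as a modest change. Among the compounds with values here, no measured step removes an acetyl group, so in this assay a modest rise is expected only tentatively. The expected step is a 2.2-fold higher number from compound 2 to compound 4 (0.34 log units; beyond the scatter) on this estimate. For compound 4 the estimate is 75 ug/mL within an expected range from 25 ug/mL to 220 ug/mL for now.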

Compound 4, solubility: 16 ug/mL
Compound 4: the middle estimate sits 4.7-fold (0.67 log units) above what was measured; the whole stated range lies above it.
By their numbers in this assay, from the lowest: compound 4; then compound 2; then compounds 3 and 1 (each within the scatter of the next).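

In this assay, 3,4-dimethylpiperazin-1-yl in place of 4-acetylpiperazin-1-yl on this carbonyl carbon gave a 2.1-fold lower number from compound 2 to compound 4 (0.33 log units; beyond the scatter), so this position responds to the group it carries, and losing the acetyl group brought no gain here. The earlier steps shown here only added a methyl, whereas this one exchanges the whole group. Nothing measured here explains the drop.

On these data alone, this single step removes the acetyl group and brings in the two methyl groups together, so their separate shares stay unknown. As far as these compounds go, how a morpholine ring or a piperazine bearing a carboxylic acid would read on this carbonyl carbon also remains open.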